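The source may hold more compounds than are shown below. What is called first, only, known or untested is meant among the compounds shown, and "the series" means these compounds.

Compound 3 `ClCc1ccc(Cn2cnc3c(Cl)nc(Cl)nc32)cc1` and compound 2 `ClCc1cccc(Cn2cnc3c(Cl)nc(Cl)nc32)c1` are built from the same atoms joined differently; the difference between the two cores is not broken down here. In a functional assay on Hs-578T cells (Homo sapiens) for cytotoxicity, read by sulforhodamine B assay, with a stated time of 48 h (a lower number here means a stronger inhibitor of growth, a higher number a weaker inhibitor of growth), compound 3 gives 5750 nM. Compound 2 gives 4360 nM in this assay, and the two numbers lie within the scatter of each other. Compound 1 `Nc1nc(Cl)c2ncn(Cc3ccc(CCl)cc3)c2n1` arises from compound 3 by amino in place of chloro on an aromatic carbon. In this assay compound 1 reaches only a limit, > 100000 nM. That makes the step of an at least 17-fold higher number from compound 3 to compound 1 (1.24 log units; beyond the scatter), which rests on (the limit of > 100000 nM in this assay, at which 1 of the 3 values shown sits). Compound 4 `Nc1nc(Cl)c2ncn(Cc3cccc(CCl)c3)c2n1` is still to be measured; it arises from compound 2 by the same change, (amino in place of chloro on an aromatic carbon). Compound 4 is expected to give about 100000 nM in this assay, somewhere from 30000 nM to 300000 nM, because the same change gave an at least 17-fold higher number from compound 3 to compound 1 (1.24 log units; beyond the scatter). The expected step is a 23-fold higher number from compound 2 to compound 4 (1.36 log units; beyond the scatter), and a limit rather than a number is thought likely.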

Compound 4, concentration for total growth inhibition: 60300 nM
Compound 4: middle estimate off by 1.7-fold (0.22 log units), on the high side; measured number inside the range.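

In this assay, amino in place of chloro on an aromatic carbon again gives a large step in the direction of weaker growth inhibition, a 14-fold higher number from compound 2 to compound 4 (1.14 log units; beyond the scatter). The direction of the change therefore carries over to the second core, and the two steps can be set side by side: the same change on two cores in this assay, an at least 17-fold higher number (1.24 log units; beyond the scatter) from compound 3 to compound 1 and a 14-fold higher number (1.14 log units; beyond the scatter) from compound 2 to compound 4; the limit leaves it open whether they differ. Compound 1 gives > 100000 nM, which is a limit and not a number, so these compounds do not show that the change has the same size on both cores.

The compounds shown leave open how other groups at that carbon, such as a methylamino group or a methoxy group, would compare with amino and chloro. They also leave open whether the step would hold on a core carrying a longer chain.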